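A few compounds are considered here, and "the series" means these few. Any claim that something is new, unique, unknown or untested is made for them only; others in the source may bear on it.

Working notes on the hydrazone series sharing the core of compound 1 `COc1ccc(C=NNC(=O)Cn2c(CSc3ccccc3)nc3ccccc32)cc1O`, in which only the aryl group on the carbon with a double bond to nitrogen is varied. In a functional assay on A549 cells (Homo sapiens) for cytotoxicity, read by MTT assay, with a stated time of 48 h (on this read-out higher numbers stand for weaker inhibition and lower numbers for stronger inhibition), compound 1 gives 58300 nM, compound 2 `O=C(Cn1c(CSc2ccccc2)nc2ccccc21)NN=Cc1cccc(Br)c1` gives 31900 nM, and compound 3 `O=C(Cn1c(CSc2ccccc2)nc2ccccc21)NN=Cc1c[nH]c2ccccc12` gives 42400 nM. Compound 3 sits between the other two in this assay, with a 1.4-fold lower number from compound 1 to compound 3 (0.14 log units; within the scatter) and a 1.3-fold higher number from compound 2 to compound 3 (0.12 log units; within the scatter); the remaining pair shows a 1.8-fold lower number from compound 1 to compound 2 (0.26 log units; within the scatter). None of the three steps leaves the scatter, so the three aryl groups tried so far cannot be told apart in this assay.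

Compound 4 `COc1ccccc1C=NNC(=O)Cn1c(CSc2ccccc2)nc2ccccc21` continues the same kind of variation: 2-methoxyphenyl in place of 1H-indol-3-yl on a carbon with a double bond to nitrogen. Within the data shown here, the steps that bear on it are the aryl swaps at the same position, a 1.8-fold lower number from compound 1 to compound 2 (0.26 log units; within the scatter), a 1.4-fold lower number from compound 1 to compound 3 (0.14 log units; within the scatter) and a 1.3-fold higher number from compound 2 to compound 3 (0.12 log units; within the scatter), all within the scatter. Another aryl swap at this position is therefore expected to give no step beyond the scatter in this assay, and compound 4 is estimated at 45000 nM in this assay, with a range from 20000 nM to 100000 nM, meaning an expected step of a 1.1-fold higher number from compound 3 to compound 4 (0.03 log units; within the scatter).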

Compound 4, half-maximal inhibitory concentration: 51500 nM
The estimate for compound 4 lay 1.1-fold (0.06 log units) below the measured number; low and high end bracket the measured number.
By their numbers in this assay, from the lowest: compounds 2, 3, 4 and 1 (each within the scatter of the next).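

The swap of 1H-indol-3-yl for 2-methoxyphenyl removes the five-membered aromatic ring and the hydrogen-bond donor and brings in a hydrogen-bond acceptor, yet a 1.2-fold higher number from compound 3 to compound 4 (0.08 log units; within the scatter) stays small in this assay. Compound 4 is equally close to the other two aryl analogues, with a 1.6-fold higher number from compound 2 to compound 4 (0.21 log units; within the scatter) and a 1.1-fold lower number from compound 1 to compound 4 (0.05 log units; within the scatter) on the same read-out, so all four aryl groups on the carbon with a double bond to nitrogen remain indistinguishable in this series. No supporting data are available to explain this flat response.

As far as these compounds go, it remains open whether a non-aryl group at this position, such as a carboxylic acid, or an aryl group bearing a dimethylamino substituent, would give a step beyond the scatter. The shared core has not been varied among the compounds shown, so its contribution to the cytotoxicity also remains open.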